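A few compounds are considered here, and "the series" means these few. Any claim that something is new, unique, unknown or untested is made for them only; others in the source may bear on it.

Compound 1, `Cc1cc(NC(=O)Nc2ccc(C(=O)O)cc2)c2ccccc2n1`, gives > 25000 nM in an ADME assay on HepG2 cells (Homo sapiens) for cytotoxicity, with a stated time of 72 h (on this read-out higher numbers stand for an effect only at larger amounts of compound and lower numbers for an effect already at smaller amounts), which is a limit of the assay and not a number.
Compound 2, `Cc1cc(NC(=O)Nc2ccc(N)cc2)c2ccccc2n1`, gives > 25000 nM in this assay, also a limit of the assay.
Compound 3, `Cc1cc(NC(=O)Nc2cccc(Cl)c2)c2ccccc2n1`, gives 19000 nM in this assay.

Among the compounds with values here, compound 3 thus carries the only number here; the other two sit at the limit of > 25000 nM in this assay, at which 2 of the 3 values shown sit. The step that the two limits leave unreadable from compound 1 to compound 2 cannot be read, while the step of an at least 1.3-fold lower number from compound 2 to compound 3 (0.11 log units; that floor lies within the scatter). Compound 4, `Cc1cc(NC(=O)Nc2ccc(F)cc2)c2ccccc2n1`, differs from compound 3 by 4-fluorophenyl in place of 3-chlorophenyl on an amide-type nitrogen. Within the data shown here, no measured step swaps one halogen-bearing phenyl for another, so the change is expected to give a step of a 1.2-fold higher number from compound 3 to compound 4 (0.06 log units; within the scatter), within the scatter. Compound 4 is therefore estimated at 22000 nM, between 12000 nM and 40000 nM, with a fair chance that only a limit is reported.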

Compound 4, half-maximal effective concentration: > 25000 nM
Compound 4: no number, only a limit (the forecaster's own chance of this, stated with the estimate: 45%); at least 1.1-fold (0.05 log units) between middle value and limit.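

The result for compound 4 is a limit of the assay and not a number. Putting 4-fluorophenyl in place of 3-chlorophenyl on the amide-type nitrogen gives an at least 1.3-fold higher number from compound 3 to compound 4 (0.11 log units; that floor lies within the scatter). A halogen-bearing phenyl at this place therefore does not always give a number in this assay, and compound 3 remains the only compound with one: the limit of > 25000 nM in this assay, at which 3 of the 4 values shown sit.

The steps from compound 1 and from compound 2 to compound 4 cannot be read, as both ends of each are limits. Going by these compounds, whether a methoxy group on this phenyl ring would give a number in this assay stays open.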